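A Fluorine Added to a Potent Steroid-Reductase Inhibitor

A few compounds are considered here, and "the series" means these few. Any claim that something is new, unique, unknown or untested is made for them only; others in the source may bear on it.

Compound 1 `O=C(O)Cc1ccc(C=C2CCN(C(=O)C(C3CCCCC3)C3CCCCC3)CC2)cc1` is the more potent of the two measured compounds: in an assay on isolated protein for inhibition of 3-oxo-5-alpha-steroid 4-dehydrogenase 2 (Homo sapiens) (a lower number here means a stronger inhibitor, a higher number a weaker inhibitor), compound 1 gives 6 nM. Compound 2 `O=C(O)c1ccc(C=C2CCN(C(=O)C(c3ccccc3)c3ccccc3)CC2)cc1` carries a different pairing of groups; in this assay compound 2 gives 530 nM, and the gap between these two numbers lies beyond the scatter. Compound 3 `O=C(O)Cc1ccc(C=C2CCN(C(=O)C(C3CCCCC3)C3CCCCC3)CC2)c(F)c1` has not been measured. It differs from compound 1 by fluoro in place of hydrogen on an aromatic carbon. Within the data shown here, no measured pair shows this change, so the estimated step of no change at the digits printed from compound 1 to compound 3 (within the scatter) is expected to be small, within the scatter. Compound 3 is therefore expected to give 6 nM in this assay, within a range from 2 nM to 18 nM.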

Compound 3, half-maximal inhibitory concentration: 7 nM
The estimate for compound 3 lay 1.2-fold (0.07 log units) below the measured number; the range from low to high includes it.
By their numbers in this assay, from the lowest: compounds 1 and 3 (each within the scatter of the next); then compound 2.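

In this assay, fluoro in place of hydrogen on an aromatic carbon, ortho to a large group, gives a 1.2-fold higher number from compound 1 to compound 3 (0.07 log units; within the scatter), so this position accepts a fluorine with no change that can be told from the scatter. This is the only pair shown that differs in one place, since compound 1 and compound 2 differ in more than one. Nothing measured here accounts for the result. Still open, going by these compounds, is whether chlorine or a methoxy group at this position would leave the number as unchanged, and whether fluoro on the other aromatic carbons would do the same.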